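Cytotoxicity series on the shared core: benzyl to cyclohexyl amide

The source may report more compounds than this note shows. Statements on the series, on what has been measured and on what is new or still open speak of the compounds shown alone.

Measured compounds in a functional assay on HeLa cells (Homo sapiens) for cytotoxicity, read by MTT assay, with a stated time of 24 h; on this read-out higher numbers stand for weaker inhibition and lower numbers for stronger inhibition:
compound 1, `C=CC1=C(C(=O)NCc2ccccc2)C(c2ccc(OC)c(OC)c2)OC1`, gives > 100000 nM, a limit of the assay.
compound 2, `C=CC1=C(C(=O)NCc2ccccc2)C(c2ccc(OC)cc2)OC1`, gives > 100000 nM, a limit of the assay.
compound 3, `C=CC1=C(C(=O)NCc2ccc(Cl)cc2)C(c2ccc(F)cc2)OC1`, gives > 100000 nM, a limit of the assay.

Compound 1 stands only at a limit, with no number of its own, and the two further values shown are limits as well, so nothing places compound 1 relative to the others. Within the data shown here, the one single-point step, from compound 1 to compound 2, reads as a step that the two limits leave unreadable from compound 1 to compound 2; the size cannot be taken from two limits. Compound 3 differs from compound 1 in more than one place, and its value shows only that it also sits at the limit. The whole picture is summed up by the limit of > 100000 nM in this assay, at which 3 of the 3 values shown sit.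

Compound 4, `C=CC1=C(C(=O)NC2CCCCC2)C(c2ccc(OC)c(OC)c2)OC1`, differs from compound 1 in one place: cyclohexyl in place of benzyl on an amide-type nitrogen. Among the measured compounds shown here, no measured step concerns an amide substituent, and the only measured step is unreadable, so no step beyond the scatter in either direction is indicated for this assay. Compound 4 is therefore expected to give 100000 nM, with a range of 30000 nM to 300000 nM, most likely again reported as a limit. The step this estimate implies, a number no higher from compound 1 to compound 4 (the limit leaves the size open), is expected to stay within the scatter.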

Compound 4, half-maximal inhibitory concentration: 5540 nM
Compound 4: middle estimate off by 18-fold (1.26 log units), on the high side, and the stated range ends above it.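

Exchange of benzyl for cyclohexyl on the amide-type nitrogen, with the rest of compound 1 unchanged, gives an at least 18-fold lower number from compound 1 to compound 4 (1.25 log units; beyond the scatter) in this assay. This makes the amide substituent the first place in the series shown to move the read-out off the limit, which the earlier compounds could not show, as the steps among them cannot be read: the limit of > 100000 nM in this assay, at which 3 of the 4 values shown sit.

The change replaces a six-membered aromatic ring of carbon only with a six-membered non-aromatic ring of carbon only, and it also shortens the benzyl group to a ring attached directly to the nitrogen, so this single pair does not separate the two differences.

A cyclohexylmethyl or a phenyl group on the same nitrogen would show which of the two differences goes with the step, and an open chain such as n-butyl would show whether a ring is needed there at all. As far as these compounds go, it also remains open whether cyclohexyl on the amide gives a measurable number with the aromatic ring of compound 2, or whether the result holds only for the dimethoxyphenyl-bearing core of compound 4.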